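Furan to thiophene on a nitropyrrole oxadiazole: cytotoxicity outlook

The source may hold more compounds than are shown below. What is called first, only, known or untested is meant among the compounds shown, and "the series" means these compounds.

Measured compounds:
- Compound 1, `Cn1cc([N+](=O)[O-])cc1-c1nnc(-c2ccco2)o1`: 191000 nM
- Compound 2, `O=[N+]([O-])c1c[nH]c(-c2nnc(-c3ccc[nH]3)o2)c1`: 227000 nM
- Compound 3, `COc1ccc(-c2nnc(-c3cc([N+](=O)[O-])cn3C)o2)cc1`: 281000 nM

Of the compounds shown here, three sharing a core have been tested in an ADME assay on Vero cells (Chlorocebus sabaeus) for cytotoxicity, read by MTT assay, with a stated time of 72 h; a lower number here means a stronger inhibitor, a higher number a weaker inhibitor. Compound 1 gives 191000 nM, compound 2 gives 227000 nM and compound 3 gives 281000 nM. Compound 1 sits at one end of this small set, but the gaps from compound 1 to compound 2 and to compound 3 both fall within the usual scatter of such measurements, so the three cannot be told apart on these numbers alone. All three show only weak effects on the cells.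

The next compound, compound 4, `Cn1cc([N+](=O)[O-])cc1-c1nnc(-c2cccs2)o1`, has not yet been tested. Its change from compound 1 is thiophen-2-yl in place of furan-2-yl on an aromatic carbon. For the measured compounds named here, no measured pair in this set shows what such a swap does here, so the expectation rests on the closeness of the three numbers already seen. For compound 4 the step of a 1.0-fold higher number from compound 1 to compound 4 (0.02 log units; within the scatter) is expected to stay within the scatter in this assay, with no clear direction. Compound 4 is therefore estimated at 200000 nM, with a range from 100000 nM to 400000 nM.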

Compound 4, half-maximal inhibitory concentration: 521000 nM
For compound 4 the middle estimate is 2.6-fold (0.42 log units) below the measured one, and the stated range ends below it.
By their numbers in this assay, from the lowest: compounds 1, 2, 3 and 4 (each within the scatter of the next, the first and the last beyond it).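

Putting thiophen-2-yl in place of furan-2-yl on this aromatic carbon gives, in this assay, a 2.7-fold higher number from compound 1 to compound 4 (0.44 log units; beyond the scatter) and so a modestly weaker effect on the cells. For the compounds shown here, this is the first single change in the set with a step that clears the scatter, which shows that the number can respond to this position. The two groups match in heavy-atom count, in hydrogen-bond donors and acceptors and in charge, so those counts alone do not predict the step, and no measurement here explains it.

This single pair cannot show whether the same swap would give a similar step on other compounds in the series. It also leaves open how an amine, a carboxylic acid or a longer alkyl chain would read at this position.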